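From Cyclopentyl to 2,4-Dichlorophenyl on an Amide-Type Nitrogen

The source may hold more compounds than are shown below. What is called first, only, known or untested is meant among the compounds shown, and "the series" means these compounds.

Compound 1 `O=C(Nc1cccc(CNc2nccnc2Cl)c1)Nc1ccccc1F` gives 6440 nM in a functional assay on MGC-803 cells (Homo sapiens) for antiproliferative activity, read by MTT assay, with a stated time of 48 h; on this read-out lower numbers stand for stronger inhibition and higher numbers for weaker inhibition.
Compound 2 `O=C(Nc1cccc(CNc2nccnc2Cl)c1)Nc1ccc(Cl)cc1Br` gives 7480 nM.
Compound 3 `O=C(Nc1cccc(CNc2nccnc2Cl)c1)NC1CCCC1` gives 23400 nM.

Compound 3 stands at the highest number of the three, set apart from both aryl-bearing compounds: a 3.6-fold higher number from compound 1 to compound 3 (0.56 log units; beyond the scatter) and a 3.1-fold higher number from compound 2 to compound 3 (0.50 log units; beyond the scatter), each a modest step beyond the scatter. Compound 4 `O=C(Nc1cccc(CNc2nccnc2Cl)c1)Nc1ccc(Cl)cc1Cl` differs from compound 3 by 2,4-dichlorophenyl in place of cyclopentyl on an amide-type nitrogen, that is, cyclopentylamino becomes (2,4-dichlorophenyl)amino. Both measured steps bear on this change in reverse: an aryl group on this nitrogen went with a lower number each time, and compound 2 shows that a halogenated phenyl gives 7480 nM. A modest step downward is therefore expected, a 3.3-fold lower number from compound 3 to compound 4 (0.52 log units; beyond the scatter), with compound 4 estimated at 7000 nM, in a range from 3500 nM to 14000 nM.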

Compound 4, half-maximal inhibitory concentration: 6430 nM
The estimate for compound 4 lay 1.1-fold (0.04 log units) above the measured number; the range from low to high includes it.
By their numbers in this assay, from the lowest: compounds 4, 1 and 2 (each within the scatter of the next); then compound 3.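

In this assay, 2,4-dichlorophenyl in place of cyclopentyl on the amide-type nitrogen gives a clear drop (a 3.6-fold lower number from compound 3 to compound 4 (0.56 log units; beyond the scatter)), so all three halogenated phenyl compounds now stand apart from compound 3. Chloro in place of bromo (a 1.2-fold lower number from compound 2 to compound 4 (0.07 log units; within the scatter)) and 2,4-dichlorophenyl in place of 2-fluorophenyl (a 1.0-fold lower number from compound 1 to compound 4 (0.00 log units; within the scatter)) both stay within the scatter, so these halogen patterns cannot be told apart here. No evidence at hand accounts for these results. Still open, going by these compounds, is whether an unsubstituted phenyl, or a phenyl carrying methoxy or a carboxylic acid, would match them, and whether an open-chain butyl would resemble cyclopentyl.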